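Swapping propyl for 1-hydroxycyclohexyl on a shared core

The source may hold more compounds than are shown below. What is called first, only, known or untested is meant among the compounds shown, and "the series" means these compounds.

Measured so far in a functional assay on MDA-MB-231 cells (Homo sapiens) for antiproliferative activity, read by sulforhodamine B assay, with a stated time of 48 h; a lower number here means a stronger inhibitor of growth, a higher number a weaker inhibitor of growth:
- compound 1 `CCCCc1cn(CCCN2C(=O)COc3ccccc32)nn1` gives 3600 nM
- compound 2 `CCCc1cn(CCCN2C(=O)COc3ccccc32)nn1` gives 1100 nM

Of these two, compound 2 holds the lower number and is the stronger inhibitor of growth. Compound 3 `O=C1COc2ccccc2N1CCCn1cc(C2(O)CCCCC2)nn1` keeps the shared core and puts 1-hydroxycyclohexyl in place of propyl on an aromatic carbon, a change counted as 1-hydroxycyclohexyl in place of propyl on an aromatic carbon and not yet measured. Going by the values given here, the only measured step that bears on this is a 3.3-fold lower number from compound 1 to compound 2 (0.51 log units; beyond the scatter) which is modest but beyond the scatter, and there the shorter chain went with the lower number. Neither measured compound carries a ring or a hydrogen-bond donor in this place, so that step is only a rough guide. Taking compound 1 at 3600 nM as the one case of a larger group, a rise of similar modest size is expected in this assay, namely a 2.3-fold higher number from compound 2 to compound 3 (0.36 log units; beyond the scatter) as an estimate. For compound 3 the estimated value is 2500 nM with an expected range from 600 nM to 9000 nM given how little is known so far.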

Compound 3, concentration for 50% growth inhibition: 1200 nM
Beside the measured number, compound 3's estimate is 2.1-fold (0.32 log units) above it; the range from low to high includes it.
By their numbers in this assay, from the lowest: compounds 2 and 3 (each within the scatter of the next); then compound 1.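

In this assay, going by these compounds alone, this position on the five-membered aromatic ring turns out to take a much larger group than the earlier compounds carried: 1-hydroxycyclohexyl has 7 heavy atoms against the 3 of propyl and adds a six-membered ring and a hydrogen-bond donor, yet a 1.1-fold higher number from compound 2 to compound 3 (0.04 log units; within the scatter) keeps the two compounds within the scatter of each other. The earlier pair suggested that a larger group goes with a higher number, but compound 3 goes against that reading, since a 3.0-fold lower number from compound 1 to compound 3 (0.48 log units; beyond the scatter) shows the larger group with the lower number when it replaces butyl, so heavy-atom count alone does not order these three compounds. No measurement is available that explains this result.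

The compounds shown do not separate the contribution of the ring from that of the hydroxyl, which a plain cyclohexyl group or a 3-hydroxypropyl chain at this position could begin to do. They also leave open how an ethyl group, an amine or a carboxylic acid here would read in this assay.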